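Nitro to chloro swap on two related cores

This account rests on a few compounds, and the source may have more. Where it says the series, first, only, none or still open, it means among the compounds named here.

Compound 1 `COc1cc(-c2ncnn2-c2ccc([N+](=O)[O-])cc2)cc(OC)c1OC` and compound 2 `COc1cc(-c2ncnn2-c2ccc(Cl)cc2)cc(OC)c1OC` share one core; compound 3 `COc1cc(-n2ncnc2-c2cccc([N+](=O)[O-])c2)cc(OC)c1OC` and the unmeasured compound 4 `COc1cc(-n2ncnc2-c2cccc(Cl)c2)cc(OC)c1OC` share another, and how the two cores differ is not broken down here. In a functional assay on HeLa cells (Homo sapiens) for antiproliferative activity, read by MTT assay, with a stated time of 72 h (a higher number here means a weaker inhibitor, a lower number a stronger inhibitor), compound 1 gives only a limit, > 10000 nM. Compound 2 also gives only a limit in this assay, > 10000 nM. The change between them, (chloro in place of nitro on an aromatic carbon), leaves a step that cannot be read, a step that the two limits leave unreadable from compound 1 to compound 2; this rests on (the limit of > 10000 nM in this assay, at which 3 of the 3 values shown sit). Compound 3 likewise gives only a limit in this assay, > 10000 nM. Compound 4 carries the same kind of change, (chloro in place of nitro on an aromatic carbon); the place differs in that the group is meta to a large group in compound 4 and para to a large group in compound 2. For compound 4 the step expected in this assay is a step that the limit leaves unreadable from compound 3 to compound 4, a guess set beside the unreadable a step that the two limits leave unreadable from compound 1 to compound 2. Compound 4 is thus expected to come out near 15000 nM, most likely again as a limit rather than a number, with 4000 nM to 60000 nM as the expected range.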

Compound 4, half-maximal inhibitory concentration: > 10000 nM
Compound 4 was reported as a limit (the forecaster's own chance of this, stated with the estimate: 80%); the middle value is on the limit's open side.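

No step can be read from compound 3 to compound 4 in this assay, because both compounds give only limits: the limit of > 10000 nM in this assay, at which 4 of the 4 values shown sit.

The compounds shown leave open whether chloro in place of nitro changes activity on either core in this assay, and which of the four compounds, if any, is the stronger inhibitor.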